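Aminoquinazoline nitriles: moving from compound 2 to compound 4

The source may hold more compounds than are shown below. What is called first, only, known or untested is meant among the compounds shown, and "the series" means these compounds.

The compounds measured so far:
compound 1, `N#Cc1c(Cl)c(Cl)c2nc(N)nc(N)c2c1Cl`, 29.7 ug/mL;
compound 2, `N#Cc1c(Nc2ccc(Cl)cc2)c(F)c2nc(N)nc(N)c2c1F`, 115 ug/mL;
compound 3, `N#Cc1c(NCc2ccccc2)c(Cl)c2nc(N)nc(N)c2c1F`, 34.1 ug/mL.

These three were tested in a functional assay on A549 cells (Homo sapiens) for cytotoxicity, read by MTT assay; on this read-out lower numbers stand for stronger inhibition and higher numbers for weaker inhibition. Compound 2 shows the highest number of the three, set apart beyond the scatter from both compound 3 and compound 1, so it is the weakest of the measured set.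

Compound 4, `CC(C)(C)Nc1c(C#N)c(F)c2c(N)nc(N)nc2c1F`, has not yet been measured. It differs from compound 2 in one place: tert-butyl in place of 4-chlorophenyl on a nitrogen on an aromatic ring. Going by the values given here, no measured pair shows this exact change, so the direction can only be guessed from the fact that compound 2 sits at the high end while compound 1 and compound 3 sit lower. The author expects a modest move toward a lower number, of a size a 1.8-fold lower number from compound 2 to compound 4 (0.25 log units; within the scatter), though a change within the scatter would not surprise. The estimate for compound 4 in this assay is 65 ug/mL, with a likely range from 25 ug/mL to 180 ug/mL.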

Compound 4, half-maximal inhibitory concentration: > 1000 ug/mL
Compound 4 was reported as a limit; the forecaster's own chance of this, stated with the estimate: 10%; middle value at least 15-fold (1.18 log units) from the limit.
By their numbers in this assay, from the lowest: compounds 1 and 3 (each within the scatter of the next); then compound 2. At a limit, above all of these: compound 4.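

In this assay, the group on this nitrogen proves to matter: tert-butyl in place of 4-chlorophenyl gives an at least 8.6-fold higher number from compound 2 to compound 4 (0.93 log units; beyond the scatter), a move toward weaker inhibition that lies beyond the scatter. Compound 4 stands as a limit and not as a number: the limit of > 1000 ug/mL in this assay, at which 1 of the 4 values shown sits. Going by these compounds alone, the earlier compounds included no pair differing in one place, so only this step shows that tert-butyl cannot stand in for 4-chlorophenyl here without a clear change in the read-out.

Going by these compounds, whether the step follows the loss of the ring, the loss of the chlorine or the branching of tert-butyl stays open. So does the effect of a plain phenyl or a cyclohexyl group on this nitrogen.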